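The source may hold more compounds than are shown below. What is called first, only, known or untested is meant among the compounds shown, and "the series" means these compounds.

Within the data shown here, in a functional assay on MDA-MB-453 cells (Homo sapiens) for cytotoxicity, read by MTT assay, with a stated time of 72 h (on this read-out higher numbers stand for weaker inhibition and lower numbers for stronger inhibition), compound 2 `CSCC[C@H](NC1=CC(=O)C=C(C[C@]2(C)[C@@H](C)CC[C@]3(C)C(C)=CCC[C@@H]23)C1=O)C(=O)O` gives 25600 nM as the lowest number so far. Compound 3 `CC(C)C[C@H](NC1=CC(=O)C=C(C(C)(C)C)C1=O)C(=O)O` gives 84900 nM and compound 1 `CC(C)(C)C1=CC(=O)C=C(NCC(=O)O)C1=O` gives 171000 nM in the same test, both beyond the scatter from compound 2. Compound 4 `CC1=CCC[C@H]2[C@](C)(CC3=CC(=O)C=C(N[C@@H](C)C(=O)O)C3=O)[C@@H](C)CC[C@]12C` keeps the rest of compound 2 and changes one chain: hydrogen in place of (methylsulfanyl)methyl on a saturated chain carbon, two bonds along the chain from an amine nitrogen and a carbonyl carbon. This puts hydrogen in place of (methylsulfanyl)methyl on a saturated chain carbon, two bonds along the chain from an amine nitrogen and a carbonyl carbon, so 2-(methylsulfanyl)ethyl becomes methyl. The closest measured change is a different one on a different compound pair, a 2.0-fold lower number from compound 1 to compound 3 (0.30 log units; within the scatter), and it stays within the scatter. On that single step, no shift beyond the scatter is expected in this assay, only an estimated 1.2-fold higher number from compound 2 to compound 4 (0.07 log units; within the scatter). For compound 4 the expected value is 30000 nM, with an estimated range from 13000 nM to 65000 nM.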

Compound 4, half-maximal inhibitory concentration: 14700 nM
The estimate for compound 4 lay 2.0-fold (0.31 log units) above the measured number; measured number inside the range.
By their numbers in this assay, from the lowest: compounds 4 and 2 (each within the scatter of the next); then compounds 3 and 1 (each within the scatter of the next).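

In this assay, going from 2-(methylsulfanyl)ethyl to methyl on the shared core gives a 1.7-fold lower number from compound 2 to compound 4 (0.24 log units; within the scatter) and stays within the scatter. This shows that, on this larger core, the (methylsulfanyl)methyl part and its sulfur can be replaced by hydrogen at this chain carbon without a readable change in the number. Nothing measured here gives a reason for this result.

From the compounds shown here alone, whether a carboxylic acid, an amine or a longer chain at this place would move the number beyond the scatter stays open. A single step within the scatter sets no trend.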